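Shortening an Ethoxy Group to Methoxy on a Shared Core

The source may report more compounds than this note shows. Statements on the series, on what has been measured and on what is new or still open speak of the compounds shown alone.

Of the compounds shown here, three built on one shared core have been tested in a functional assay on A-375 cells (Homo sapiens) for antiproliferative activity, read by MTT assay, with a stated time of 24 h, tested at 0.01 ug/mL; on this read-out lower numbers stand for a weaker effect and higher numbers for a stronger effect at the one concentration tested. Compound 1 `CCc1ccc2nc(C(=O)Nc3c(F)cc(-c4cccc(F)c4)cc3F)c(C)c(C(=O)O)c2c1` gives -0.45%. Compound 2 `Cc1c(C(=O)Nc2c(F)cc(-c3cccc(F)c3)cc2F)nc2ccc(F)cc2c1C(=O)O`, which carries fluoro in place of ethyl on an aromatic carbon, gives -0.56%. Compound 3 `CCOc1ccc2nc(C(=O)Nc3c(F)cc(-c4cccc(F)c4)cc3F)c(C)c(C(=O)O)c2c1` gives 0.3%, the highest of the three numbers, but the steps of a number 0.8 percentage points higher from compound 1 to compound 3 (within the scatter) and a number 0.9 percentage points higher from compound 2 to compound 3 (within the scatter) show that all three sit within the scatter of one another, so none can be called more active than the rest at this concentration.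

Compound 4 `COc1ccc2nc(C(=O)Nc3c(F)cc(-c4cccc(F)c4)cc3F)c(C)c(C(=O)O)c2c1` differs from compound 3 by hydrogen in place of methyl on a saturated chain carbon bound to an oxygen on an aromatic ring. Within the data shown here, no measured pair shows a methoxy at this place; the only steps that touch this aromatic carbon are the two just named, which brought in the ethoxy, and both stayed within the scatter. Compound 4 is therefore expected to show a number 0.2 percentage points lower from compound 3 to compound 4 (within the scatter) in this assay, nothing beyond the scatter. For compound 4 the estimated value in this assay is 0.1%, within a range from -4% to 4%.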

Compound 4, a percentage reported as inhibition, at one concentration (the size of the read-out at that concentration, not a potency): 0.05%
Beside the measured number, compound 4's estimate is 0.1 percentage points above it, within the range that was stated.
By their numbers in this assay, from the lowest: compounds 2, 1, 4 and 3 (each within the scatter of the next).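

In this assay the ethoxy group of compound 3 can be shortened to methoxy, the same change as ethyl to methyl, with only a small shift (a number 0.3 percentage points lower from compound 3 to compound 4 (within the scatter)). Methoxy also stays level with the other two groups at this aromatic carbon, with fluoro (a number 0.6 percentage points higher from compound 2 to compound 4 (within the scatter)) and with ethyl (a number 0.5 percentage points higher from compound 1 to compound 4 (within the scatter)), so fluoro, ethyl, ethoxy and methoxy cannot be told apart here at the one concentration tested. No measurement is available that would explain why these numbers stay so close.

On these data alone, whether an amine or a longer chain such as butoxy on this aromatic carbon would give a number beyond the scatter stays open. So does whether these four compounds would separate at a higher concentration.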